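Swapping a methoxyethyl for a cyclopropyl on the amine

The compounds below may be only part of what the source reports. "The series", "measured", "known", "first", "only" and "open" are said of these compounds alone.

Compound 1 `COc1ccc(CNCc2c(-c3nnc(SC(C)C)n3-c3ccccc3)n(C)c3ccc(F)cc23)cc1`: 6.42
Compound 2 `COCCNCc1c(-c2nnc(SC(C)C)n2-c2ccccc2)n(C)c2ccc(F)cc12`: 4.52

In a physicochemical assay for lipophilicity (a lower number here means a more polar compound, a higher number a more lipophilic compound), compound 1 gives 6.42. Compound 2 gives 4.52, the lower of the two numbers. Compound 3 `CC(C)Sc1nnc(-c2c(CNC3CC3)c3cc(F)ccc3n2C)n1-c1ccccc1` differs from compound 2 by cyclopropyl in place of 2-methoxyethyl on an amine nitrogen. Going by the values given here, the only measured step, a number 1.90 log units lower from compound 1 to compound 2 (beyond the scatter), exchanged an aromatic ring for a short chain on the same amine nitrogen, a different kind of change, so it guides the present step only loosely. A modest rise is expected, a number 0.58 log units higher from compound 2 to compound 3 (beyond the scatter). Compound 3 is therefore expected to give 5.1, with a likely range from 4.6 to 5.6.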

Compound 3, partition coefficient: 4.97
Compound 3: the middle estimate sits 0.13 log units above what was measured, and the stated range covers the measured number.
By their numbers in this assay, from the lowest: compound 2; then compound 3; then compound 1.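

Cyclopropyl in place of 2-methoxyethyl on the amine nitrogen gives a number 0.45 log units higher from compound 2 to compound 3 (beyond the scatter) in this assay, so a swap between two small groups still moves the number here. Cyclopropyl in place of 4-methoxybenzyl gives a number 1.45 log units lower from compound 1 to compound 3 (beyond the scatter), a much larger step, which leaves compound 3 far closer to compound 2 than to compound 1. Nothing available explains either step. The compounds shown leave open where a plain ethyl chain, a longer carbon chain or a carboxylic acid on this nitrogen would fall.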